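A few compounds are considered here, and "the series" means these few. Any claim that something is new, unique, unknown or untested is made for them only; others in the source may bear on it.

Measured compounds in a functional assay on K562 cells (Homo sapiens) for inhibition, read by sulforhodamine B assay, with a stated time of 48 h; on this read-out lower numbers stand for stronger inhibition of growth and higher numbers for weaker inhibition of growth:
- compound 1 `COc1cc(-c2cc(/C=C/C(=O)c3ccc(Cl)c(Cl)c3)[nH]n2)cc(OC)c1OC` gives 4960 nM
- compound 2 `COc1ccc(-c2cc(/C=C/C(=O)c3ccc(N)cc3)[nH]n2)cc1OC` gives 2030 nM
- compound 3 `COc1ccc(-c2cc(/C=C/C(=O)c3cc(OC)c(OC)c(OC)c3)[nH]n2)cc1OC` gives 730 nM

Compound 1 stands at the highest number of the three in this assay, the weakest growth inhibition of the set. Compound 2 sits nearest to it, with a lower number that lies beyond the scatter; compound 3 lies furthest away, with a markedly lower number, also beyond the scatter. Among the measured compounds shown here, no two of these three differ in a single place, so no single step between measured compounds can be read off.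

The next compound, compound 4 `COc1ccc(C(=O)/C=C/c2cc(-c3cc(OC)c(OC)c(OC)c3)n[nH]2)cc1OC`, is compared with compound 1 as follows: 3,4-dimethoxyphenyl in place of 3,4-dichlorophenyl on a carbonyl carbon. The aryl ring on the carbonyl carbon thus exchanges its two chlorines for two methoxy groups, while the rest of the shared core is kept. Compound 3, which also carries methoxy-substituted aryl rings at both ends, gives 730 nM in this assay, the lowest number of the set. For the measured compounds named here, on that basis the step from compound 1 to compound 4 is expected to lower the number beyond the scatter, though its exact size remains uncertain with no direct pair to lean on. The expected step is a 4.5-fold lower number from compound 1 to compound 4 (0.65 log units; beyond the scatter). Compound 4 is therefore estimated at 1100 nM, within a range of 400 nM to 3200 nM.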

Compound 4, concentration for 50% growth inhibition: 1910 nM
Estimate against measurement, compound 4: 1.7-fold (0.24 log units) below, within the range that was stated.
By their numbers in this assay, from the lowest: compound 3; then compounds 4 and 2 (each within the scatter of the next); then compound 1.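

In this assay, among the compounds shown here, replacing 3,4-dichlorophenyl with 3,4-dimethoxyphenyl on a carbonyl carbon gives a 2.6-fold lower number from compound 1 to compound 4 (0.41 log units; beyond the scatter), the only single-place step so far, and it shows that growth inhibition responds to the substituents on this aryl ring while the rest of the shared core stays fixed. The change is not a clean test of one feature: two chlorines leave and two methoxy groups enter, so the heavy-atom count and the hydrogen-bond acceptor count rise together, and this one pair cannot separate the loss of chlorine from the gain of methoxy. No measurement in hand accounts for the size of the step.

Compound 2 and compound 3 each differ from compound 4 in more than one place, so their gaps cannot be read as steps at this position. On these data alone, it remains open whether a single methoxy group, an unsubstituted phenyl, a hydroxyl group or an amine on this ring would lower the number further, leave it unchanged or raise it, and whether the same exchange would give a step of similar size on a different shared core.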